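The compounds below may be only part of what the source reports. "The series", "measured", "known", "first", "only" and "open" are said of these compounds alone.

In a functional assay on DU-145 cells (Homo sapiens) for inhibition, read by trypan blue exclusion, with a stated time of 96 h (on this read-out higher numbers stand for weaker inhibition of growth and lower numbers for stronger inhibition of growth), compound 1 (`O=C(/C(=C\c1ccc(F)c([N+](=O)[O-])c1)S(=O)(=O)c1ccc(Br)cc1)c1ccc(Br)cc1`) gives 25000 nM, level with compound 3 (`COc1ccc(S(=O)(=O)/C(=C/c2ccc(C)s2)C(=O)c2ccc(Cl)cc2)cc1`) at 25000 nM. Compound 2 (`O=C(O)c1ccc(C(=O)/C(=C\c2ccc(Cl)c([N+](=O)[O-])c2)SCc2ccc(Cl)cc2)cc1`) gives 1000 nM, a lower number by a margin beyond the scatter, so compound 1 sits with compound 3 at the high end of the three values. Compound 4 (`O=C(/C(=C\c1csc([N+](=O)[O-])c1)S(=O)(=O)c1ccc(Br)cc1)c1ccc(Br)cc1`) carries 5-nitrothiophen-3-yl in place of 4-fluoro-3-nitrophenyl on a double-bonded chain carbon bound to a double-bonded chain carbon. Within the data shown here, no two measured compounds differ in one place only, so nothing measured isolates this change. The expected step, a 1.7-fold lower number from compound 1 to compound 4 (0.22 log units; within the scatter), is estimated to lie within the scatter, with any shift more likely towards a lower number. For compound 4 the estimated value is 15000 nM, with an expected range of 4000 nM to 40000 nM.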

Compound 4, concentration for 50% growth inhibition: 1000 nM
For compound 4 the middle estimate is 15-fold (1.18 log units) above the measured one, and the stated range ends above it.
By their numbers in this assay, from the lowest: compounds 2 and 4 (each within the scatter of the next); then compounds 1 and 3 (each within the scatter of the next).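

In this assay the place on a double-bonded chain carbon bound to a double-bonded chain carbon proves sensitive: 5-nitrothiophen-3-yl in place of 4-fluoro-3-nitrophenyl gives a 25-fold lower number from compound 1 to compound 4 (1.40 log units; beyond the scatter) with the rest of the structure unchanged. Among these compounds, the earlier compounds differed in several places at once, so this is the first single change that can be read, and it lies beyond the scatter.

Open: whether the gain depends on the thiophene ring or on its nitro group, and whether a furan ring or an amine at this place would hold the lower number. No measurement on hand gives a reason for the size of the step.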